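The source may report more compounds than this note shows. Statements on the series, on what has been measured and on what is new or still open speak of the compounds shown alone.

Measured so far:
compound 1, `Cc1csc(NC(=O)Cn2cc(-c3ccncc3)nn2)n1`, 100 nM
compound 2, `Cc1cc(NC(=O)Cn2cc(-c3ccncc3)nn2)no1`, 430 nM
compound 3, `Cc1csc(NC(=O)Cn2cc(-c3cccs3)nn2)n1`, 40 nM

All three were tested in a functional assay on BMDM cells (Mus musculus, strain C57BL/6) for inhibition, with a stated time of 2 days; a lower number here means a stronger inhibitor, a higher number a weaker inhibitor. Compound 1 and compound 2 differ by 5-methyl-1,2-oxazol-3-yl in place of 4-methyl-1,3-thiazol-2-yl on an amide-type nitrogen, and that change gave a 4.3-fold higher number from compound 1 to compound 2 (0.63 log units; beyond the scatter). The cores of compound 1 and compound 3 differ by thiophen-2-yl in place of pyridin-4-yl on an aromatic carbon, which gave a 2.5-fold lower number from compound 1 to compound 3 (0.40 log units; beyond the scatter). Compound 4, `Cc1cc(NC(=O)Cn2cc(-c3cccs3)nn2)no1`, is not yet measured; it differs from compound 3 by 5-methyl-1,2-oxazol-3-yl in place of 4-methyl-1,3-thiazol-2-yl on an amide-type nitrogen, the same change seen in two pairs among the compounds shown, at a place described in the same words in both. For compound 4 the step expected is a 4.3-fold higher number from compound 3 to compound 4 (0.63 log units; beyond the scatter), beside the measured 4.3-fold higher number from compound 1 to compound 2 (0.63 log units; beyond the scatter), resting on compound 1 at 100 nM and compound 2 at 430 nM. Compound 4 is therefore estimated at 170 nM, expected between 70 nM and 450 nM.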

Compound 4, half-maximal inhibitory concentration: > 30000 nM
Compound 4 was reported as a limit; the forecaster's own chance of this, stated with the estimate: 2%; at least 170-fold (2.24 log units) between middle value and limit.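

In this assay, compound 4 gives > 30000 nM, which is a limit of the assay and not a number. Placing 5-methyl-1,2-oxazol-3-yl in place of 4-methyl-1,3-thiazol-2-yl on the amide-type nitrogen gave an at least 750-fold higher number from compound 3 to compound 4 (2.87 log units; beyond the scatter), so this change did not carry from one core to the other at the same size: the same change on two cores in this assay, a 4.3-fold higher number (0.63 log units; beyond the scatter) from compound 1 to compound 2 and an at least 750-fold higher number (2.87 log units; beyond the scatter) from compound 3 to compound 4, at least 170-fold (2.24 log units) apart, beyond the scatter of two such steps. Thiophen-2-yl in place of pyridin-4-yl gave an at least 69-fold higher number from compound 2 to compound 4 (1.84 log units; beyond the scatter), so that change did not keep its direction either, although these four compounds do not show why the two changes depend on each other: the same change on two cores in this assay, a 2.5-fold lower number (0.40 log units; beyond the scatter) from compound 1 to compound 3 and an at least 69-fold higher number (1.84 log units; beyond the scatter) from compound 2 to compound 4, at least 170-fold (2.24 log units) apart, beyond the scatter of two such steps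

The compounds shown leave open whether a different group on the amide-type nitrogen, such as a phenyl ring, would follow compound 1 and compound 3 or compound 4. They also leave open how a carboxylic acid on the shared core would behave.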